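Working notes on compound 4: a change at the carbonyl

The source may report more compounds than this note shows. Statements on the series, on what has been measured and on what is new or still open speak of the compounds shown alone.

Of the compounds shown here, three have been measured in a functional assay on MIA PaCa-2 cells (Homo sapiens) for inhibition, read by MTT assay, with a stated time of 7 days; on this read-out higher numbers stand for weaker inhibition and lower numbers for stronger inhibition. Compound 1 `CCN(CC)C(=O)c1ccc(S(=O)(=O)N2CCC[C@@H](C(=O)N3CCC(F)(F)CC3)C2)cc1` gives 70 nM, compound 2 `CC(C)S(=O)(=O)c1ccc(S(=O)(=O)N2CCC[C@@H](C(=O)N3CCC(F)(F)CC3)C2)cc1` gives 11 nM, and compound 3 `CCN(CC)S(=O)(=O)c1ccc(S(=O)(=O)N2CCC[C@@H](C(=O)N3CC[C@@H](OC)C3)C2)cc1` gives 3910 nM. Among the measured compounds shown here, the only single-point step within the set is a 6.4-fold lower number from compound 1 to compound 2 (0.80 log units; beyond the scatter), and it concerns the group on the aromatic carbon, not the carbonyl. Compound 3 stands at the highest number of the three; compound 1 is its nearest neighbour and compound 2 lies furthest from it. For the measured compounds named here, compound 3 differs from each of them at two places, so no single step leads to it.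

Compound 4 `CCN(CC)S(=O)(=O)c1ccc(S(=O)(=O)N2CCC[C@@H](C(=O)N[C@H]3CCOC3)C2)cc1` differs from compound 3 in one place: (oxolan-3-yl)amino in place of 3-methoxypyrrolidin-1-yl on a carbonyl carbon. Going by the values given here, no measured step touches a carbonyl carbon, and the single known step, on the aromatic substituent, offers no guide to direction or size here. Nothing in the set shows a change at this position moving the number beyond the scatter. The expected step in this assay is a 1.0-fold higher number from compound 3 to compound 4 (0.01 log units; within the scatter), which amounts to no change beyond the scatter. Compound 4 is therefore estimated at 4000 nM, within a range from 1300 nM to 12000 nM.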

Compound 4, half-maximal inhibitory concentration: 1670 nM
Estimate against measurement, compound 4: 2.4-fold (0.38 log units) above; the range from low to high includes it.
By their numbers in this assay, from the lowest: compound 2; then compound 1; then compound 4; then compound 3.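

Among the compounds shown here, the change at this carbonyl carbon gives the first measured step at this position: in this assay, (oxolan-3-yl)amino in place of 3-methoxypyrrolidin-1-yl gives a 2.3-fold lower number from compound 3 to compound 4 (0.37 log units; beyond the scatter), so the number here does respond to the group on the carbonyl, though only modestly. The entering group has 1 hydrogen-bond donor against 0 for the leaving group and 6 heavy atoms against 7, while each has one five-membered non-aromatic ring; this single step cannot show which difference goes with the lower number. No supporting evidence bears on why the number moves.

On these data alone, whether the same exchange gives a like step with isopropylsulfonyl or diethylcarbamoyl on the aromatic carbon remains open. Also open, as far as these compounds go, is how an open-chain dimethylamino group or an unsubstituted amino group on the carbonyl carbon would read.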